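Amide substituent on the shared core: cyclohexyl versus benzyl

The source may report more compounds than this note shows. Statements on the series, on what has been measured and on what is new or still open speak of the compounds shown alone.

Measured in a functional assay on HCT-116 cells (Homo sapiens) for cytotoxicity, read by MTT assay, with a stated time of 72 h; on this read-out higher numbers stand for weaker inhibition and lower numbers for stronger inhibition:
- compound 1 `N[C@H]1CC[C@H](Nc2c(C(=O)NCc3ccc(F)cc3)nc(Br)c3cccnc23)CC1`: 7000 nM
- compound 2 `N[C@H]1CC[C@H](Nc2c(C(=O)NC3CCCCC3)nc(Br)c3cccnc23)CC1`: > 10000 nM (a limit of the assay)

Compound 2 has no number in this assay, only a limit (the limit of > 10000 nM in this assay, at which 1 of the 2 values shown sits). Its place on the scale is therefore open.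

The next entry is compound 3 `N[C@H]1CC[C@H](Nc2c(C(=O)NCc3ccccc3)nc(Br)c3cccnc23)CC1`, and the change is benzyl in place of cyclohexyl on an amide-type nitrogen. In words, benzyl takes the place of cyclohexyl on an amide-type nitrogen.

Among the compounds with values here, one measured step bears on this change, and it concerns the same nitrogen: an at least 1.4-fold higher number from compound 1 to compound 2 (0.15 log units; that floor lies within the scatter). There, cyclohexyl replaced 4-fluorobenzyl. The present change runs the other way, from cyclohexyl to benzyl, so a small move towards a lower number is expected, though it may stay within the scatter. Going by these compounds, with only a floor on the measured step, its true size is unknown. Compound 1 gives 7000 nM, and this value serves as the anchor.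

The expected move is an at least 1.4-fold lower number from compound 2 to compound 3 (0.15 log units; that floor lies within the scatter). Compound 3 is estimated at 7000 nM, with an expected range from 3000 nM to 15000 nM.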

Compound 3, half-maximal inhibitory concentration: 7000 nM
For compound 3 middle estimate and measured number coincide at the digits printed; the range from low to high includes it.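

In this assay, the fluoro on the benzyl group proves dispensable at this amide-type nitrogen, with hydrogen in place of fluoro on an aromatic carbon giving no change at the digits printed from compound 1 to compound 3 (within the scatter). The unsubstituted benzyl group thus shows that the earlier comparison with cyclohexyl did not depend on the fluoro, and benzyl in place of cyclohexyl gives an at least 1.4-fold lower number from compound 2 to compound 3 (0.15 log units; that floor lies within the scatter), a floor that does not by itself separate the two groups. The true size of the step stays unknown because compound 2 carries only a limit: the limit of > 10000 nM in this assay, at which 1 of the 3 values shown sits.

The compounds shown vary only the amide substituent, so it stays open whether a phenethyl group on that nitrogen, or a methoxy or dimethylamino group in place of the fluoro, would shift the number beyond the scatter. Going by these compounds, the effect of replacing the bromo group or the aminocyclohexyl group on the shared core also stays open, as does whether any such change would carry over to other cell lines.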